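Trifluoromethyl in place of two methyls on the thiourea aryl ring

The source may report more compounds than this note shows. Statements on the series, on what has been measured and on what is new or still open speak of the compounds shown alone.

Compound 1 `CNC(=O)c1ccc(Oc2cccc(NC(=S)Nc3ccc(C)c(C)c3)c2)nc1` gives 38600 nM in a functional assay on MDA-MB-231 cells (Homo sapiens) for antiproliferative activity, read by MTT assay; a lower number here means a stronger inhibitor, a higher number a weaker inhibitor.
Compound 2 `CNC(=O)c1ccc(Oc2cccc(NC(=S)Nc3ccc(Br)c(C(F)(F)F)c3)c2)nc1` gives 3020 nM.
Compound 3 `CNC(=O)c1ccc(Oc2cccc(NC(=S)Nc3ccc(F)cc3)c2)nc1` gives 21700 nM.

Among these three, compound 1 has the highest number. Among the compounds with values here, the one single-point step recorded, a 1.8-fold lower number from compound 1 to compound 3 (0.25 log units; within the scatter), lies within the scatter, so compound 1 and compound 3 cannot be told apart. Compound 2, which carries both bromine and a trifluoromethyl group on that ring, shows a markedly lower number than compound 1, though the two differ in more than one place.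

Compound 4 `CNC(=O)c1ccc(Oc2cccc(NC(=S)Nc3cccc(C(F)(F)F)c3)c2)nc1` is the next member: 3-(trifluoromethyl)phenyl in place of 3,4-dimethylphenyl on an amide-type nitrogen. Because compound 2, also trifluoromethyl-bearing, gives 3020 nM, compound 4 is expected to come in below compound 1, though less far, at an estimated 10000 nM (range 3000 nM to 30000 nM). That expectation corresponds to a 3.9-fold lower number from compound 1 to compound 4 (0.59 log units; beyond the scatter).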

Compound 4, half-maximal inhibitory concentration: 38100 nM
Beside the measured number, compound 4's estimate is 3.8-fold (0.58 log units) below it, and the stated range ends below it.
By their numbers in this assay, from the lowest: compound 2; then compounds 3, 4 and 1 (each within the scatter of the next).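

In this assay, 3-(trifluoromethyl)phenyl on this nitrogen gives no clear change from the earlier aryl groups, with a 1.0-fold lower number from compound 1 to compound 4 (0.01 log units; within the scatter) and a 1.8-fold higher number from compound 3 to compound 4 (0.24 log units; within the scatter). The large step comes with hydrogen in place of bromo on an aromatic carbon, which gives a 13-fold higher number from compound 2 to compound 4 (1.10 log units; beyond the scatter), so within this pair the low number of compound 2 goes with bromo, not with trifluoromethyl alone. No measurement here offers an explanation for this step.

On these data alone, whether bromo gives a low number without trifluoromethyl remains open. So does whether chloro or methoxy on that aromatic carbon would match bromo.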